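This account rests on a few compounds, and the source may have more. Where it says the series, first, only, none or still open, it means among the compounds named here.

Measured so far:
compound 1, `Oc1ccccc1-n1ccnc1`, which in an assay on cells for inhibition of Indoleamine 2,3-dioxygenase 1 (Homo sapiens), read by HPLC, with a stated time of 20 min (a higher number here means a weaker inhibitor, a lower number a stronger inhibitor), gives 16000 nM
compound 2, `Oc1ccc(Cl)cc1-n1ccnc1`, which in this assay gives 2100 nM
compound 3, `Oc1ccccc1-c1nnc[nH]1`, which in this assay gives 31000 nM

Compound 1 and compound 2 share one core and differ in a single place: chloro in place of hydrogen on an aromatic carbon. That one change produced a 7.6-fold lower number from compound 1 to compound 2 (0.88 log units; beyond the scatter). Compound 3 is built on a second core; how the two cores differ is not broken down here. The numbers for compound 3 and compound 1 lie within the usual scatter of each other, so no order between them can be read from the data, whereas the gap between compound 3 and compound 2 is beyond the scatter.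

Compound 4, `Oc1ccc(Cl)cc1-c1nnc[nH]1`, has not yet been measured. It stands to compound 3 as compound 2 stands to compound 1: chloro in place of hydrogen on an aromatic carbon. The place of the change is described in the same words for both pairs, so this is the same change carried onto the other core. For the measured compounds named here, the only guide is the step seen once between compound 1 and compound 2, and the expectation for compound 4 rests on that step alone. Compound 4 is expected to give about 4500 nM in this assay, with a range from 1500 nM to 14000 nM. This corresponds to an expected step of a 6.9-fold lower number from compound 3 to compound 4 (0.84 log units; beyond the scatter). The range is kept wide: the step has been observed only once, and on the other core.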

Compound 4, half-maximal inhibitory concentration: 600 nM
The estimate for compound 4 lay 7.5-fold (0.88 log units) above the measured number, and the stated range ends above it.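

Carried onto the second core, chloro in place of hydrogen on an aromatic carbon again lowered the number in this assay, giving a 52-fold lower number from compound 3 to compound 4 (1.71 log units; beyond the scatter), so the direction of the step held on both cores while its size did not: the same change on two cores in this assay, a 7.6-fold lower number (0.88 log units; beyond the scatter) from compound 1 to compound 2 and a 52-fold lower number (1.71 log units; beyond the scatter) from compound 3 to compound 4, 6.8-fold (0.83 log units) apart, beyond the scatter of two such steps. For a newcomer, the practical reading is that, in these two pairs, the earlier step pointed the right way but did not fix how large the step on the other core would be, so a step measured on one core is a guide to direction here and not a number to copy. What this does not show is why the step is larger on the core of compound 3, or whether the same direction would hold on any further core, since the comparison rests on just one pair of compounds for each core.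

Chloro is the only group shown here on an aromatic carbon para to a hydroxy group, so it remains open whether fluoro, bromo, a methyl group or an amine at that place would lower the number as well. Also open, from the compounds shown here alone, is how either core would respond to chloro placed elsewhere on the six-membered ring, or to a methoxy group in place of the hydroxy group.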